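Benzylamine aryl variation in a sulfonamide series

The source may hold more compounds than are shown below. What is called first, only, known or untested is meant among the compounds shown, and "the series" means these compounds.

Measured in a functional assay on MIA PaCa-2 cells (Homo sapiens) for inhibition, read by MTT assay, with a stated time of 72 h; a higher number here means a weaker inhibitor of growth, a lower number a stronger inhibitor of growth:
- compound 1 `O=S(=O)(NCCCNCc1ccccc1)c1cc(C(F)(F)F)cc(C(F)(F)F)c1`: 11000 nM
- compound 2 `O=S(=O)(NCCCNCc1cccc2ccccc12)c1cc(C(F)(F)F)cc(C(F)(F)F)c1`: 2800 nM
- compound 3 `O=S(=O)(NCCCNCc1ccc(-c2ccccc2)cc1)c1cc(C(F)(F)F)cc(C(F)(F)F)c1`: 2400 nM

Compound 3 gives the lowest number of the three, but its gap to compound 2 lies within the scatter, so the two cannot be ordered; only compound 1 sits clearly apart. Compound 4 `O=S(=O)(NCCCNCc1ccc(Cl)cc1)c1cc(C(F)(F)F)cc(C(F)(F)F)c1` differs from compound 3 by chloro in place of phenyl on an aromatic carbon, placed para to a large group. The step that bears on it is a 4.6-fold lower number from compound 1 to compound 3 (0.66 log units; beyond the scatter), which compound 4 partly reverses: the phenyl leaves and a single chloro enters. The step of a 3.9-fold lower number from compound 1 to compound 2 (0.59 log units; beyond the scatter) shows the same pattern, a larger aryl giving a lower number. Compound 4 is therefore expected to fall between compound 1 and compound 3, with an upward step of roughly a 2.5-fold higher number from compound 3 to compound 4 (0.40 log units; beyond the scatter) estimated. Compound 4 is estimated at 6000 nM, range 2500 nM to 14000 nM.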

Compound 4, concentration for 50% growth inhibition: 2800 nM
The estimate for compound 4 lay 2.1-fold (0.33 log units) above the measured number, and the stated range covers the measured number.
By their numbers in this assay, from the lowest: compounds 3, 2 and 4 (each within the scatter of the next); then compound 1.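

In this assay, the lower number does not depend on a second aromatic ring: with a 3.9-fold lower number from compound 1 to compound 4 (0.59 log units; beyond the scatter), a single chloro on the aromatic carbon does what the larger aryl groups do. The step of a 1.2-fold higher number from compound 3 to compound 4 (0.07 log units; within the scatter) and the step of no change at the digits printed from compound 2 to compound 4 (within the scatter) leave compound 4 unseparated from compound 3 and compound 2, so size alone does not order these groups, and compound 4 goes against the earlier larger-aryl pattern. No data given here explain this result.

Open, going by these compounds, is whether fluoro, methyl or methoxy on this carbon would match chloro. Also open, on these data alone, is whether chloro on another carbon of the ring would give the same number.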